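Oxan-4-yl in place of tert-butyl on the ring amine

The source may hold more compounds than are shown below. What is called first, only, known or untested is meant among the compounds shown, and "the series" means these compounds.

Compound 1 (`CN1C[C@H](C(=O)Nc2cccnc2)[C@@H](c2ccc(/C=C/C(=O)Nc3ccccc3N)cc2)C1`) and compound 2 (`CC(C)(C)N1C[C@H](C(=O)Nc2ccc(Cl)cc2)[C@@H](c2ccc(/C=C/C(=O)Nc3ccccc3N)cc2)C1`) share one core but differ in more than one place. In an in vitro ADME assay on microsomes from liver (Homo sapiens) for pharmacokinetics, read by LC-MS, with a stated time of 10 min, tested at 1 uM (a higher number here means faster removal of the compound, a lower number slower removal), compound 1 gives 10 mL/min/kg and compound 2 gives 8 mL/min/kg and these two numbers lie within the scatter of each other. Among the compounds with values here, compound 2 thus stands level with the only other measured compound. Compound 3 (`Nc1ccccc1NC(=O)/C=C/c1ccc([C@H]2CN(C3CCOCC3)C[C@@H]2C(=O)Nc2ccc(Cl)cc2)cc1`) departs from compound 2 in one place: oxan-4-yl in place of tert-butyl on an amine nitrogen in a ring. Within the data shown here, no measured pair shows this change alone. The expectation therefore rests loosely on compound 1 at 10 mL/min/kg and compound 2 at 8 mL/min/kg with different groups on that nitrogen. No step beyond the scatter is expected in this assay in either direction, and the estimate is a slight rise, a 1.1-fold higher number from compound 2 to compound 3 (0.05 log units; within the scatter) in this measure. For compound 3 the estimated value is 9 mL/min/kg with an expected range from 5 mL/min/kg to 17 mL/min/kg around it.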

Compound 3, clearance: 12 mL/min/kg
Compound 3: the middle estimate sits 1.3-fold (0.12 log units) below what was measured, and the stated range covers the measured number.
By their numbers in this assay, from the lowest: compounds 2, 1 and 3 (each within the scatter of the next).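

In this assay, replacing tert-butyl with oxan-4-yl on the amine nitrogen in the ring gives a 1.5-fold higher number from compound 2 to compound 3 (0.18 log units; within the scatter), and this is the only pair shown that isolates the change. The earlier compounds shown here differed in more than one place, whereas this step shows that this position accepts a six-membered non-aromatic ring with 1 hetero atom in place of a group with no ring, without a step beyond the scatter in this measure. Nothing available bears on the reason for this reading.

The compounds shown leave open whether an amine-bearing group such as piperidin-4-yl, a carboxylic acid or a longer chain on this nitrogen would also stay within the scatter. They also leave open whether oxan-4-yl would read the same way with the amide group of compound 1 in place of the (4-chlorophenyl)carbamoyl group.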